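A few compounds are considered here, and "the series" means these few. Any claim that something is new, unique, unknown or untested is made for them only; others in the source may bear on it.

Working notes on the amide series. The shared core carries an acetamide side chain whose nitrogen substituents vary. Compound 1 `CCCN(CCC)C(=O)Cc1c(-c2ccc(OC)cc2)nn2c(CC)cc(CC)nc12` gives 5.57 nM in an assay on C6 cells for displacement of a labelled ligand from Translocator protein (Rattus norvegicus), read by scintillation counting, with a stated time of 2 h; on this read-out higher numbers stand for weaker inhibition and lower numbers for stronger inhibition. Compound 2 `CCCCCN(CCCCC)C(=O)Cc1c(-c2ccc(OC)cc2)nn2c(CC)cc(CC)nc12` gives 2.17 nM in this assay, and compound 3 `CCc1cc(CC)n2nc(-c3ccc(OC)cc3)c(CC(=O)N(C(C)CC)C(C)CC)c2n1` gives 14.4 nM. Compound 3 thus stands highest of the three: the step of a 2.6-fold higher number from compound 1 to compound 3 (0.41 log units; beyond the scatter) and the step of a 6.6-fold higher number from compound 2 to compound 3 (0.82 log units; beyond the scatter) both run upward, while the step of a 2.6-fold lower number from compound 1 to compound 2 (0.41 log units; beyond the scatter) runs the other way, so within these three the dipentyl amide sits lowest and the branched amide highest.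

Compound 4 `CCc1cc(CC)n2nc(-c3ccc(OC)cc3)c(CC(=O)N3CCC3)c2n1` is not yet measured. It differs from compound 3 by azetidin-1-yl in place of bis(sec-butyl)amino on a carbonyl carbon. For the measured compounds named here, no measured step covers a cyclic amine on this carbonyl, so the expectation rests only on the three open-chain amides. The entering group carries fewer heavy atoms than any amine so far, and the one move toward fewer carbons, from compound 2 to compound 1, gave a higher number. A modest further rise is therefore expected, and for compound 4 an estimated value of 30 nM is set, between 8 nM and 120 nM, which would mean an expected step of a 2.1-fold higher number from compound 3 to compound 4 (0.32 log units; beyond the scatter).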

Compound 4, inhibition constant: 87.8 nM
Compound 4: middle estimate off by 2.9-fold (0.47 log units), on the low side; low and high end bracket the measured number.
By their numbers in this assay, from the lowest: compound 2; then compound 1; then compound 3; then compound 4.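

In this assay, for the compounds shown here, azetidin-1-yl on the carbonyl carbon brings the first ring to this position, and the change gives a 6.1-fold higher number from compound 3 to compound 4 (0.79 log units; beyond the scatter) while the comparisons with the open-chain amides give a 16-fold higher number from compound 1 to compound 4 (1.20 log units; beyond the scatter) and a 40-fold higher number from compound 2 to compound 4 (1.61 log units; beyond the scatter) as the largest steps so far. The number at this position can therefore move much further than the modest steps among compound 1, compound 2 and compound 3 showed, and the smallest amine now stands highest, although size alone does not order the series, since the branched compound 3 stands above the unbranched compound 1. No measurement on hand explains the rise.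

From the compounds shown here alone, whether it follows from the ring or from the small size of azetidin-1-yl stays open. Pyrrolidin-1-yl, piperidin-1-yl or open-chain dimethylamino on the same carbonyl carbon would separate the two.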